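This account rests on a few compounds, and the source may have more. Where it says the series, first, only, none or still open, it means among the compounds named here.

Measured compounds: compound 1 `Cc1ccccc1NC(=O)/C=C/c1coc2cc(O)ccc2c1=O`, compound 2 `COc1cccc(NC(=O)/C=C/c2coc3cc(OC)ccc3c2=O)c1`, compound 3 `COc1ccc2c(=O)c(/C=C/C(=O)Nc3ccc(F)cc3)coc2c1`.

In a functional assay on A549 cells (Homo sapiens) for inhibition, read by MTT assay, with a stated time of 48 h (on this read-out higher numbers stand for weaker inhibition and lower numbers for stronger inhibition), compound 2 gives 12800 nM and compound 3 gives 26800 nM. Compound 1 gives only a limit of the assay, > 100000 nM, so its true value is not known. Compound 4 `COc1ccc(NC(=O)/C=C/c2coc3cc(O)ccc3c2=O)cc1` is not yet measured; it differs from compound 1 by 4-methoxyphenyl in place of 2-methylphenyl on an amide-type nitrogen. One measured step also swaps the ring on the amide-type nitrogen: a 2.1-fold higher number from compound 2 to compound 3 (0.32 log units; beyond the scatter). That swap is a different one, and the core of its two compounds differs from the core shared by compound 1 and compound 4, so it bears only loosely here. Because compound 1 sits at the limit of > 100000 nM in this assay, at which 1 of the 3 values shown sits, any measurable step can only go downward. Compound 4 is expected to give about 40000 nM, within 10000 nM to 100000 nM. This estimate means an expected step of an at least 2.5-fold lower number from compound 1 to compound 4 (0.39 log units; beyond the scatter), with a limit again possible.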

Compound 4, half-maximal inhibitory concentration: 12800 nM
Compound 4: middle estimate off by 3.1-fold (0.49 log units), on the high side; the range from low to high includes it.
By their numbers in this assay, from the lowest: compounds 2 and 4 (each within the scatter of the next); then compound 3. At a limit, above all of these: compound 1.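

Within the data shown here, compound 4 is the first compound on the core of compound 1 to give a measured number rather than a limit in this assay. Swapping 2-methylphenyl for 4-methoxyphenyl on the amide-type nitrogen gives an at least 7.8-fold lower number from compound 1 to compound 4 (0.89 log units; beyond the scatter). That size is only a lower bound, and the true step may be larger: the limit of > 100000 nM in this assay, at which 1 of the 4 values shown sits.

The change removes one group and adds another, so the shown compounds leave open which of the two drives the step. On these data alone, how an amine or a carboxylic acid on that phenyl ring would read also remains open.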